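The source may hold more compounds than are shown below. What is called first, only, known or untested is meant among the compounds shown, and "the series" means these compounds.

Series around the shared core of compound 1 `S=c1oc(-c2ccc3c(c2)OCCO3)nn1CN1CCN(C(c2ccccc2)c2ccccc2)CC1`, compound 2 `Cc1ccc(N2CCN(Cn3nc(-c4ccc5c(c4)OCCO5)oc3=S)CC2)c(C)c1`, compound 3 `S=c1oc(-c2ccc3c(c2)OCCO3)nn1CN1CCN(c2cccc(Cl)c2Cl)CC1` and compound 4 `S=c1oc(-c2ccc3c(c2)OCCO3)nn1CN1CCN(c2cccc(Cl)c2)CC1`, all read in a functional assay on BGC-823 cells (Homo sapiens) for antiproliferative activity, read by MTT assay, with a stated time of 48 h; a lower number here means a stronger inhibitor, a higher number a weaker inhibitor.

Compound 1 reports only a limit, > 50000 nM, in this assay. Compound 2 gives 28300 nM. Compound 3 gives 22600 nM, the lowest of the two numbers shown, and the step of a 1.3-fold lower number from compound 2 to compound 3 (0.10 log units; within the scatter) sets it close to compound 2. One of the three values sits at the limit (the limit of > 50000 nM in this assay, at which 1 of the 3 values shown sits).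

Compound 4 is not yet measured. Its change from compound 3 is hydrogen in place of chloro on an aromatic carbon. Among the compounds with values here, the only measured step that touches the same ring, a 1.3-fold lower number from compound 2 to compound 3 (0.10 log units; within the scatter), exchanged the whole aryl group and stayed within the scatter; no measured step removes a single chloro. Taking that step as the nearest guide, compound 4 is expected to sit near compound 3, the estimated step being a 1.2-fold higher number from compound 3 to compound 4 (0.09 log units; within the scatter), with no direction beyond the scatter. Compound 4 is therefore estimated at 28000 nM, between 12000 nM and 60000 nM.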

Compound 4, half-maximal inhibitory concentration: > 50000 nM
Compound 4: only a limit was reported; the forecaster's own chance of this, stated with the estimate: 25%; middle value at least 1.7-fold (0.25 log units) away from the limit.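

In this assay, within the data shown here, the single change from 2,3-dichlorophenyl to 3-chlorophenyl gives an at least 2.2-fold higher number from compound 3 to compound 4 (0.34 log units; beyond the scatter), the first step to lie beyond the scatter, whereas the exchange of the whole aryl group gave a 1.3-fold lower number from compound 2 to compound 3 (0.10 log units; within the scatter). Measured against 2,4-dimethylphenyl, the 3-chlorophenyl group gives an at least 1.7-fold higher number from compound 2 to compound 4 (0.24 log units; that floor lies within the scatter), so that comparison sets no clear separation. Both new steps are floors and not sizes because the reading for compound 4 is a limit: the limit of > 50000 nM in this assay, at which 2 of the 4 values shown sit.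

On these data alone, whether a fluoro, a methyl or a methoxy on that same aromatic carbon would hold the number of compound 3 stays open. Also open, as far as these compounds go, is how far compound 4 lies past its limit.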